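This account rests on a few compounds, and the source may have more. Where it says the series, first, only, none or still open, it means among the compounds named here.

Series notes, an assay on isolated protein (blood) for antagonist activity at C-C chemokine receptor type 4 (Homo sapiens), read by flow cytometry, with a stated time of 30 min; on this read-out higher numbers stand for weaker binding and lower numbers for tighter binding:

compound 1 `CC(=O)NCc1cccc(Cn2nc(NS(=O)(=O)c3ccc(Cl)s3)c3c(Cl)cccc32)c1` gives 6310 nM
compound 2 `COc1cccc2c1c(NS(=O)(=O)c1ccc(Cl)s1)nn2Cc1cccc(CNC(=O)C2COC2)c1` gives 1000 nM
compound 3 `COc1cccc2c1c(NS(=O)(=O)c1ccc(Cl)s1)nn2Cc1cccc(CNC(=O)C2CCCO2)c1` gives 794 nM

Compound 3 holds the lowest of the three numbers in this assay; compound 2 stands within the scatter of it, while compound 1 lies beyond the scatter. Compound 4 `COc1cccc2c1c(NS(=O)(=O)c1ccc(Cl)s1)nn2Cc1cccc(CNC(=O)C2CCOCC2)c1` differs from compound 3 in one place: oxan-4-yl in place of oxolan-2-yl on a carbonyl carbon. For the measured compounds named here, the only measured step that bears on this change is the earlier ring swap on a carbonyl carbon, a 1.3-fold lower number from compound 2 to compound 3 (0.10 log units; within the scatter), which stayed within the scatter. With one saturated oxygen ring exchanged for another at this position, no step beyond the scatter is expected in this assay, so the expected change is a 1.0-fold higher number from compound 3 to compound 4 (0.00 log units; within the scatter). Compound 4 is therefore estimated at 800 nM, with a range of 400 nM to 1600 nM.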

Compound 4, dissociation constant: 501 nM
The estimate for compound 4 lay 1.6-fold (0.20 log units) above the measured number; measured number inside the range.
By their numbers in this assay, from the lowest: compounds 4, 3 and 2 (each within the scatter of the next); then compound 1.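

In this assay, the six-membered oxan-4-yl ring on the carbonyl carbon stays within the scatter of both smaller oxygen rings: a 1.6-fold lower number from compound 3 to compound 4 (0.20 log units; within the scatter) and a 2.0-fold lower number from compound 2 to compound 4 (0.30 log units; within the scatter). Across the oxetan-3-yl, oxolan-2-yl and oxan-4-yl groups, neither ring size nor the point of attachment produces a step beyond the scatter. Nothing available explains these small steps.

Still open, as far as these compounds go, is whether cyclohexyl, which lacks the ring oxygen, would keep the number within the scatter. A piperidin-4-yl ring, which carries an amine, poses the same question.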